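Swapping the carbamate aryl group on a PANC-1 inhibition series

The compounds below may be only part of what the source reports. "The series", "measured", "known", "first", "only" and "open" are said of these compounds alone.

Measured compounds:
compound 1, `CC(C)=CCC/C(C)=C/CC1Cc2c(OCCCNC(=O)c3ccco3)cc(=O)n(CCCO)c2CC1(C)C`: 2.8%
compound 2, `COc1cccc(NC(=O)Oc2cc(=O)n(CCCO)c3c2CC(C/C=C(\C)CCC=C(C)C)C(C)(C)C3)c1`: 11.3%

Both compounds were run in a functional assay on PANC-1 cells (Homo sapiens) for inhibition, read by MTT assay, with a stated time of 24 h, tested at 10 uM; on this read-out higher numbers stand for more inhibition at the one concentration tested (going by the name of the read-out) and lower numbers for less inhibition. Compound 1 gives 2.8% in this assay, and compound 2 gives 11.3%. Going by the values given here, of the two numbers, that of compound 2 is the higher, but the only measured step, a number 8.5 percentage points higher from compound 1 to compound 2 (within the scatter), is within the scatter, so the two compounds cannot be separated on this read-out.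

Compound 3, `CC(C)=CCC/C(C)=C/CC1Cc2c(OC(=O)Nc3ccc(F)c(F)c3)cc(=O)n(CCCO)c2CC1(C)C`, has not yet been measured. It differs from compound 2 in one place: 3,4-difluorophenyl in place of 3-methoxyphenyl on an amide-type nitrogen. Among the compounds with values here, the measured step from compound 1 to compound 2 concerns a different part of the molecule, the group on the oxygen on the aromatic ring, and not the aryl group on the amide-type nitrogen, so no measured step bears directly on the change to compound 3. With a single measured step that is itself within the scatter, nothing in the data points to a shift beyond the scatter in this assay, and the step of a number 1.3 percentage points lower from compound 2 to compound 3 (within the scatter) is expected to be small.

Compound 3 is therefore estimated to give 10% in this assay, with a range from 0% to 25%.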

Compound 3, a percentage reported as inhibition, at one concentration (the size of the read-out at that concentration, not a potency): 4.8%
For compound 3 the middle estimate is 5.2 percentage points above the measured one; the measured number falls inside the stated range.
By their numbers in this assay, from the lowest: compounds 1, 3 and 2 (each within the scatter of the next).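

In this assay, going by these compounds alone, putting 3,4-difluorophenyl in place of 3-methoxyphenyl on the amide-type nitrogen gives a number 6.5 percentage points lower from compound 2 to compound 3 (within the scatter), which is the first measured change at this place and shows that these two aryl groups cannot be separated on this read-out. Putting (3,4-difluorophenyl)carbamoyl in place of 3-(((furan-2-yl)carbonyl)amino)propyl on the oxygen on the aromatic ring gives a number 2 percentage points higher from compound 1 to compound 3 (within the scatter), so with this aryl group too, the carbamate cannot be told apart from the group it replaces. No measurement is at hand that would bear on these results.

Going by these compounds, whether a benzyl or cyclohexyl group in place of the aryl group on the amide-type nitrogen, or a carboxylic acid or an amine carried on that aryl group, would move the number beyond the scatter stays open. The compounds shown also leave open how this series would compare at other concentrations or over other exposure times, since each one is represented here by a single reading.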